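Phenyl for isopropyl on a 5-HT7 ligand series

The source may report more compounds than this note shows. Statements on the series, on what has been measured and on what is new or still open speak of the compounds shown alone.

Compound 1 `CC(C)c1ccccc1N1CCN(CCCCC(=O)N2Cc3ccccc3C[C@H]2C(N)=O)CC1` was tested in an assay on HEK293 cells for displacement of a labelled ligand from 5-hydroxytryptamine receptor 7 (Homo sapiens), with a stated time of 1 h; on this read-out lower numbers stand for stronger inhibition and higher numbers for weaker inhibition; in this assay compound 1 gives 30 nM. Compound 2 `NC(=O)[C@@H]1Cc2ccccc2CN1C(=O)CCCCN1CCN(c2ccccc2-c2ccccc2)CC1` carries the change (phenyl in place of isopropyl on an aromatic carbon), and in this assay compound 2 gives 12 nM, a step of a 2.5-fold lower number from compound 1 to compound 2 (0.40 log units; beyond the scatter). Compound 3 `CC(C)c1ccccc1N1CCN(CCCCCC(=O)N2Cc3ccccc3C[C@H]2C(=O)N2CCCCC2)CC1` shares the same change of tail with compound 1 but the difference between the two cores is not broken down here; in this assay compound 3 gives 40 nM. Compound 4 `O=C([C@@H]1Cc2ccccc2CN1C(=O)CCCCCN1CCN(c2ccccc2-c2ccccc2)CC1)N1CCCCC1`, not yet measured, differs from compound 3 by phenyl in place of isopropyl on an aromatic carbon, the same change as that made from compound 1 to compound 2. Because the earlier step of a 2.5-fold lower number from compound 1 to compound 2 (0.40 log units; beyond the scatter) is modest yet beyond the scatter, a step of similar size, a 2.5-fold lower number from compound 3 to compound 4 (0.40 log units; beyond the scatter), is expected. In this assay compound 4 is estimated at 16 nM, with a likely range from 7 nM to 38 nM.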

Compound 4, inhibition constant: 9 nM
For compound 4 the middle estimate is 1.8-fold (0.25 log units) above the measured one; measured number inside the range.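

In this assay, phenyl in place of isopropyl on an aromatic carbon gives a 4.4-fold lower number from compound 3 to compound 4 (0.65 log units; beyond the scatter), so the number falls on this core as it did on the core of compound 1. The two steps run in the same direction and cannot be told apart in size: the same change on two cores in this assay, a 2.5-fold lower number (0.40 log units; beyond the scatter) from compound 1 to compound 2 and a 4.4-fold lower number (0.65 log units; beyond the scatter) from compound 3 to compound 4, 1.8-fold (0.25 log units) apart, within the scatter of two such steps. Within the data shown here, this rests on only two pairs in a single assay, so it shows that the change carried over here, but not that it would do so on other cores, nor why the number falls.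

The compounds shown leave open whether a cyclohexyl or pyridyl group in the same place would lower the number as phenyl does. They also leave open whether the step would hold with a carboxylic acid in place of the amide.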